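A few compounds are considered here, and "the series" means these few. Any claim that something is new, unique, unknown or untested is made for them only; others in the source may bear on it.

Measured in a functional assay on IMR-32 cells (Homo sapiens) for antiproliferative activity, read by MTT assay; on this read-out lower numbers stand for stronger inhibition and higher numbers for weaker inhibition:
- Compound 1 `CC1(C)CCc2cc(C(=O)/C=C/c3ccc(OCc4cn(-c5ccc(Cl)cc5)nn4)cc3)c(O)cc2O1`: 92100 nM
- Compound 2 `CC1(C)CCc2cc(C(=O)/C=C/c3ccc(OCc4cn(-c5ccc(Br)cc5)nn4)cc3)c(O)cc2O1`: 69400 nM
- Compound 3 `CC1(C)CCc2c(ccc(C(=O)/C=C/c3ccc(OCc4cn(-c5ccc(Br)cc5)nn4)cc3)c2O)O1`: 117000 nM

Compound 1 stands in the middle of these three numbers, and neither of the others lies beyond the scatter from it. All three numbers are high on this assay, so inhibition is weak throughout.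

Compound 4 `CCCCCn1cc(COc2ccc(/C=C/C(=O)c3cc4c(cc3O)OC(C)(C)CC4)cc2)nn1` has not yet been measured. It carries pentyl in place of 4-chlorophenyl on an aromatic nitrogen of the five-membered aromatic ring with 3 nitrogen: pentyl in place of 4-chlorophenyl on an aromatic nitrogen.

Among the compounds with values here, only one measured step bears on this site. Bromo in place of chloro on the same aryl group gave a 1.3-fold lower number from compound 1 to compound 2 (0.12 log units; within the scatter), which is within the scatter. That step keeps the ring, so it says little about losing it. Within the data shown here, no measured compound lacks this aryl group, which leaves the expectation loose.

No shift beyond the scatter is expected, and the estimated step is a 1.2-fold lower number from compound 1 to compound 4 (0.06 log units; within the scatter). The expected value for compound 4 is 80000 nM, with an estimated range of 30000 nM to 200000 nM.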

Compound 4, half-maximal inhibitory concentration: "not active" (no number reported)
Compound 4 has no reported number here, so the estimate cannot be set against anything.
By their numbers in this assay, from the lowest: compounds 2, 1 and 3 (each within the scatter of the next).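

Within the data shown here, compound 4 is reported only as "not active", without a number, so no step from compound 1 to compound 4 can be read. The compounds shown leave open how pentyl compares with 4-chlorophenyl in size of effect. No supporting data bear on this result.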